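Bromo in place of chloro: thermodynamic solubility notes

A few compounds are considered here, and "the series" means these few. Any claim that something is new, unique, unknown or untested is made for them only; others in the source may bear on it.

Measured so far:
compound 1, `CS(=O)(=O)NC(=O)CCc1cn(-c2ccc(Br)cc2)nc1-c1ccc(Cl)cc1`: 170000 nM
compound 2, `CS(=O)(=O)NC(=O)CCc1cn(-c2ccc(Cl)cc2)nc1-c1ccc(Cl)cc1`: 100000 nM
compound 3, `CS(=O)(=O)NC(=O)/C=C/c1cn(-c2ccc(Cl)cc2)nc1-c1ccncc1`: 90000 nM

In a physicochemical assay for solubility, in phosphate buffer, measured as thermodynamic solubility, at pH 7.4 (on this read-out higher numbers stand for higher solubility and lower numbers for lower solubility), compound 1 gives 170000 nM, compound 2 gives 100000 nM and compound 3 gives 90000 nM. All three numbers lie within the scatter of one another, so no order among them is claimed.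

One change is seen twice in the series. Between compound 2 and compound 1 it is bromo in place of chloro on an aromatic carbon, and in this assay it made a 1.7-fold higher number from compound 2 to compound 1 (0.23 log units; within the scatter). The difference between the core of compound 2 and the core of compound 3 is not broken down here. Compound 4, `CS(=O)(=O)NC(=O)/C=C/c1cn(-c2ccc(Br)cc2)nc1-c1ccncc1`, stands to compound 3 as compound 1 stands to compound 2: the change is bromo in place of chloro on an aromatic carbon, the same change, at a place described in the same words.

With a single earlier step to rest on, the expectation is that compound 4 shows about a 1.3-fold higher number from compound 3 to compound 4 (0.12 log units; within the scatter) in this assay, beside a 1.7-fold higher number from compound 2 to compound 1 (0.23 log units; within the scatter), because the earlier pair gave a 1.7-fold higher number from compound 2 to compound 1 (0.23 log units; within the scatter) and that step sat within the scatter. Compound 4 is therefore estimated at 120000 nM, with a range of 50000 nM to 300000 nM.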

Compound 4, solubility: 115000 nM
Beside the measured number, compound 4's estimate is 1.0-fold (0.02 log units) above it; the measured number falls inside the stated range.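

In this assay the change from 4-chlorophenyl to 4-bromophenyl gave a 1.3-fold higher number from compound 3 to compound 4 (0.11 log units; within the scatter) on one core and a 1.7-fold higher number from compound 2 to compound 1 (0.23 log units; within the scatter) on the other, so each of the two pairs stays within the scatter. Going by these compounds alone, this shows that on these two cores the change produced no step that can be told apart from repeat variation, and the estimate carried across from the earlier pair is compatible with that; it does not show a real effect of the change, nor that a shared direction in two such small steps means anything, and two pairs say nothing of any further core. Nothing at hand bears on what lies behind either step.

The compounds shown carry only chloro or bromo at this place, so how an amine or a carboxylic acid there would read in this assay remains open. Within the data shown here, also open is whether the change would carry over to a core with a longer chain in place of the one these compounds hold.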